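This account rests on a few compounds, and the source may have more. Where it says the series, first, only, none or still open, it means among the compounds named here.

Compound 1 `Cc1ccccc1-c1cnc(NC(=O)c2ccc(F)cc2)n1C` in a toxicity assay on THP-1 cells (Homo sapiens) for inhibition; a lower number here means that less compound is tolerated, a higher number that more compound is tolerated: compound 1 gives > 50000 nM, which is a limit of the assay and not a number.
Compound 2 `COc1ccc(-c2cnc(NC(=O)CCc3ccccc3)n2C)cc1` in this assay: compound 2 gives > 100000 nM, again a limit rather than a number.
Compound 3 `Cc1ccc(C(=O)Nc2ncc(-c3ccccc3)n2C)cc1` in this assay: compound 3 gives > 50000 nM, also a limit.

All three compounds share a core, and none of them reached a half-maximal cytotoxic concentration within the tested range. Compound 2 sits at the limit of > 100000 nM in this assay, at which 1 of the 3 values shown sits. The other two sit at the limit of > 50000 nM in this assay, at which 2 of the 3 values shown sit. Compound 2 thus stands among the three with its tolerated concentration known only as the higher of the two limits, and no number ranks it against the others.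

Compound 4 `COc1ccc(-c2cnc(NC(=O)c3ccccc3O)n2C)cc1` has not yet been measured in this assay. It differs from compound 2 in one place: 2-hydroxyphenyl in place of phenethyl on a carbonyl carbon. No measured pair among the three shown differs in a single place, so there is no measured step to lean on. What the three values do show is that every group tried on the carbonyl carbon left the compound untoxic within range. The step is therefore expected to be none beyond the scatter: a number no higher from compound 2 to compound 4 (the limit leaves the size open). Compound 4 is expected to give 100000 nM, with a range from 30000 nM to 300000 nM, and most likely only a limit will again be reported.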

Compound 4, half-maximal cytotoxic concentration: > 100000 nM
Compound 4: a limit, no number (the forecaster's own chance of this, stated with the estimate: 80%); the middle value sits exactly at the limit.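

In this assay compound 4 gives > 100000 nM, a limit of the assay and not a number, and compound 2 is likewise known only as a limit, so no step can be read between them. The compounds shown leave open the concentration at which any of them would harm these cells, and whether 2-hydroxyphenyl and phenethyl differ at all.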